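Dimethylphenyl Isomers on the Sulfonyl Sulfur

The source may hold more compounds than are shown below. What is called first, only, known or untested is meant among the compounds shown, and "the series" means these compounds.

Of the compounds shown here, three built on one shared core have been measured in an assay on isolated protein for displacement of a labelled ligand from metabotropic glutamate receptor 5 (Homo sapiens), with a stated time of 60 min, tested at 1 uM; on this read-out lower numbers stand for less inhibition and higher numbers for more inhibition at the one concentration tested (going by the name of the read-out). Compound 1 `COc1ccc(S(=O)(=O)c2cnc3ccc(C)cc3c2N2CCC(C)CC2)cc1Cl` gives 93%, compound 2 `Cc1ccc(S(=O)(=O)c2cnc3ccc(Cl)cc3c2N2CCC(C)CC2)cc1C` gives 84%, and compound 3 `Cc1cc(C)cc(S(=O)(=O)c2cnc3ccc(C)cc3c2N2CCC(C)CC2)c1` gives 80%. Compound 3 holds the lowest of the three numbers; its gap to compound 2 lies within the scatter, while the step of a number 13 percentage points lower from compound 1 to compound 3 (beyond the scatter) lies beyond it and is modest.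

Compound 4 `Cc1ccc2ncc(S(=O)(=O)c3ccc(C)c(C)c3)c(N3CCC(C)CC3)c2c1` has not yet been measured. It differs from compound 3 by 3,4-dimethylphenyl in place of 3,5-dimethylphenyl on a sulfonyl sulfur. Among the measured compounds shown here, no measured step changes only the arrangement of the two methyl groups on this ring. For the measured compounds named here, the one step that touches the aryl group on the sulfonyl sulfur, a number 13 percentage points lower from compound 1 to compound 3 (beyond the scatter), exchanged the whole group and was modest. Compound 2 also carries a 3,4-dimethylphenyl on the sulfonyl sulfur, though its core differs, and compound 2 gives 84%.

On this basis the expected step of a number 4 percentage points higher from compound 3 to compound 4 (within the scatter) stays within the scatter. Compound 4 is therefore expected to give 84%, with a likely range from 70% to 95%.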

Compound 4, a percentage reported as inhibition, at one concentration (the size of the read-out at that concentration, not a potency): 90%
Compound 4: middle estimate off by 6 percentage points, on the low side, within the range that was stated.
By their numbers in this assay, from the lowest: compounds 3, 2, 4 and 1 (each within the scatter of the next, the first and the last beyond it).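

In this assay, among the compounds shown here, the step of a number 10 percentage points higher from compound 3 to compound 4 (within the scatter) gives the first reading on the arrangement of the two methyl groups alone, and it does not separate the two arrangements beyond the scatter. For the compounds shown here, the step of a number 3 percentage points lower from compound 1 to compound 4 (within the scatter) shows that an exchange of the whole aryl group on the sulfonyl sulfur can also stay within the scatter, unlike the exchange that gave compound 3, while the step of a number 6 percentage points higher from compound 2 to compound 4 (within the scatter) gives a first reading on methyl in place of chloro on an aromatic carbon. Nothing available gives a reason for any of these steps.

On these data alone, whether an amine or a carboxylic acid on this aryl group would leave the number in the same region remains open. As far as these compounds go, it is also open whether methyl in place of chloro would give a similar step with 3,5-dimethylphenyl or 3-chloro-4-methoxyphenyl on the sulfonyl sulfur.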